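The source may report more compounds than this note shows. Statements on the series, on what has been measured and on what is new or still open speak of the compounds shown alone.

Series notes. Compound 1 `COc1ccc(-c2cc(/C=C/C(=O)c3ccc(N)cc3)[nH]n2)cc1` carries a single methoxy group on its terminal aromatic ring and an amino-substituted ketone side. In a functional assay on NCI-H460 cells (Homo sapiens) for cytotoxicity, read by sulforhodamine B assay, with a stated time of 48 h, tested at 0.1 uM (a lower number here means a stronger effect, a higher number a weaker effect of the compound at the concentration tested), compound 1 gives 102%. Compound 2 `COc1cc(-c2cc(/C=C/C(=O)c3ccc(F)c(F)c3)[nH]n2)cc(OC)c1OC` carries three methoxy groups and a difluoro ketone side; in this assay compound 2 gives 102%. Compound 1 thus stands level with compound 2 at the digits reported, the two values lying within the usual scatter, and neither compound shows an effect distinguishable from baseline at this concentration. Compound 3 `COc1ccc(-c2cc(/C=C/C(=O)c3ccc(N)cc3)[nH]n2)cc1OC` differs from compound 1 by methoxy in place of hydrogen on an aromatic carbon, ortho to a methoxy group. Going by the values given here, no measured pair isolates that change. Among the compounds with values here, since compound 1 gives 102% and no compound here departs from that level, the step of a number 2 percentage points lower from compound 1 to compound 3 (within the scatter) is expected to be nil beyond the scatter. Compound 3 is therefore estimated at 100%, within 88% to 110%.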

Compound 3, a percentage reported as activity, at one concentration (the size of the read-out at that concentration, not a potency): 100%
For compound 3 middle estimate and measured number coincide at the digits printed, and the stated range covers the measured number.
By their numbers in this assay, from the lowest: compounds 3, 1 and 2 (each within the scatter of the next).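

In this assay, going by these compounds alone, methoxy in place of hydrogen on an aromatic carbon, ortho to a methoxy group, gives a number 2 percentage points lower from compound 1 to compound 3 (within the scatter), and this is the only single-place change so far. At the one concentration tested, this position therefore shows no response to the change, and compound 3 stays level with compound 1, which the unpaired earlier compounds could not show. Nothing at hand explains this result. As far as these compounds go, whether a hydroxy group or a chlorine atom at this position would read any differently remains open. Also open, from the compounds shown here alone, is whether the same methoxy step would stay within the scatter with the difluoro ketone side of compound 2 in place of the amino-substituted ketone side, or at a higher concentration.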